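The compounds below may be only part of what the source reports. "The series", "measured", "known", "first", "only" and "open" are said of these compounds alone.

Of the compounds shown here, three sharing one core have been tested in a functional assay on MDA-MB-231 cells (Homo sapiens) for antiproliferative activity, read by MTT assay; a higher number here means a weaker inhibitor, a lower number a stronger inhibitor. Compound 1 `CCCCCCCCCCCCCCCCCCCC1(O)CC(=O)c2c(O)cc(O)cc2O1` reaches only a limit of that assay, > 87000 nM. Compound 3 `CCCCCCCCCCCC1(O)CC(=O)c2c(O)cc(O)cc2O1` gives 42800 nM, the higher of the two numbers recorded, and compound 2 `CC/C=C\C/C=C\C/C=C\CCCCCCCC1(O)CC(=O)c2c(O)cc(OCOC)cc2O1` gives 6790 nM. Among the measured compounds shown here, the single measured step, an at least 2.0-fold lower number from compound 1 to compound 3 (0.30 log units; that floor lies within the scatter), points toward a lower number with the shorter saturated chain, though its floor sits within the scatter. Compound 4 `CC/C=C\C/C=C\C/C=C\CCCCCCCC1(O)CC(=O)c2c(O)cc(O)cc2O1` is compound 3 with a group of 10 heavy atoms (10 carbon; no ring) in place of a group of 4 heavy atoms (4 carbon; no ring), on a saturated chain carbon, seven bonds along the chain from a saturated ring carbon. Its chain matches that of compound 2, whose number sits far below that of compound 3, while the added length alone recalls compound 1. Weighing both, a moderate lowering is expected, a 2.9-fold lower number from compound 3 to compound 4 (0.46 log units; beyond the scatter). For compound 4 the estimate is 15000 nM, between 5000 nM and 50000 nM.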

Compound 4, half-maximal inhibitory concentration: 6790 nM
The estimate for compound 4 lay 2.2-fold (0.34 log units) above the measured number; the measured number falls inside the stated range.
By their numbers in this assay, from the lowest: compounds 2 and 4 (each within the scatter of the next); then compound 3. At a limit, above all of these: compound 1.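

In this assay, putting the longer group with its 3 double bonds in place of butyl, on this saturated chain carbon, gives a 6.3-fold lower number from compound 3 to compound 4 (0.80 log units; beyond the scatter). A longer group here can therefore go with a lower number, although length and double bonds enter together. Replacing methoxymethyl with hydrogen on the oxygen on the aromatic ring gives no change at the digits printed from compound 2 to compound 4 (within the scatter), so this change leaves the number unmoved with this chain.

Open, from the compounds shown here alone, is whether a saturated chain of that length, or one carrying a carboxylic acid, would match compound 4. Nothing measured here explains the lower number of compound 4.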